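Cytotoxicity of compound 1 and its piperazine extension

The source may report more compounds than this note shows. Statements on the series, on what has been measured and on what is new or still open speak of the compounds shown alone.

Measured in an ADME assay on CHO cells (Cricetulus griseus) for cytotoxicity, read by MTT assay; on this read-out higher numbers stand for lower toxicity in this test and lower numbers for higher toxicity in this test:
compound 1 `Fc1ccc(-c2nc3c(N4CCNCC4)nccc3[nH]2)cc1F` gives 8100 nM
compound 2 `Fc1ccc(-c2nc3c(N4CCCNCC4)nccc3[nH]2)cc1F` gives 7200 nM
compound 3 `NC1CCN(c2nccc3[nH]c(-c4ccc(F)c(F)c4)nc23)CC1` gives 8200 nM

The steps from compound 1 to both other measured compounds lie within the scatter, so the three values form one group with no order among them. The change 1-methylpiperidin-4-yl in place of hydrogen on an amine nitrogen in a ring leads from compound 1 to compound 4 `CN1CCC(N2CCN(c3nccc4[nH]c(-c5ccc(F)c(F)c5)nc34)CC2)CC1` and leaves the shared core as it is. Among the compounds with values here, two measured steps bear on it: a 1.1-fold lower number from compound 1 to compound 2 (0.05 log units; within the scatter) and a 1.0-fold higher number from compound 1 to compound 3 (0.01 log units; within the scatter) with neither going beyond the scatter. Within the data shown here, both replace the whole piperazin-1-yl, and no measured compound carries a substituent on that amine nitrogen, so they are only a loose guide and the range must stay wide. In this assay, among the measured compounds shown here, no step clearly beyond the scatter is expected, with a slight lean towards a lower number that rests on judgement and not on a measured step. The estimated step is a 1.4-fold lower number from compound 1 to compound 4 (0.13 log units; within the scatter) and may well stay within the scatter. The estimate for compound 4 is 6000 nM (expected range 2200 nM to 15000 nM).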

Compound 4, half-maximal cytotoxic concentration: 33000 nM
For compound 4 the middle estimate is 5.5-fold (0.74 log units) below the measured one; measured number above the stated range.
By their numbers in this assay, from the lowest: compounds 2, 1 and 3 (each within the scatter of the next); then compound 4.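

In this assay, within the data shown here, 1-methylpiperidin-4-yl in place of hydrogen on the amine nitrogen in the ring gives a 4.1-fold higher number from compound 1 to compound 4 (0.61 log units; beyond the scatter) and is the only step in this set beyond the scatter, towards lower toxicity in this test. The earlier steps shown here replaced the whole piperazin-1-yl and left compound 1, compound 2 and compound 3 as one group, whereas this result shows that substitution on the amine nitrogen itself can move the read-out. No available evidence accounts for this shift.

Going by these compounds, whether the step depends on the whole 1-methylpiperidin-4-yl or would also appear with a single methyl group, an acetyl group or a piperidin-4-yl lacking its methyl remains open. On these data alone, it is also open whether the same substituent would give a similar step on the 1,4-diazepan-1-yl of compound 2.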